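The source may hold more compounds than are shown below. What is called first, only, known or untested is meant among the compounds shown, and "the series" means these compounds.

Measured in an ADME assay on Caco-2 cells (Homo sapiens) for inhibition, read by sulforhodamine B assay, with a stated time of 72 h; a higher number here means a weaker inhibitor, a lower number a stronger inhibitor:
- Compound 1 `COc1cc(/C=C/C(=O)/C=C(/C=C/c2ccc(OC(C)=O)c(OC)c2)NC2CCCCC2)ccc1OC(C)=O`: > 25000 nM (a limit)
- Compound 2 `CCCNC(=C\C(=O)/C=C/c1ccc(O)c(OC)c1)/C=C/c1ccc(O)c(OC)c1`: > 25000 nM (a limit)

Compound 2 has no numerical value, only a limit: compound 2 reads > 25000 nM. For the measured compounds named here, the same holds for the other measured compound, as the series so far shows (the limit of > 25000 nM in this assay, at which 2 of the 2 values shown sit). From the compounds shown here alone, no number therefore places compound 2 within the series, and the true distance of either compound from the limit is unknown.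

The next compound is compound 3 `COc1cc(/C=C/C(=O)/C=C(/C=C/c2ccc(O)c(OC)c2)NCC(C)C)ccc1O`. The change is methyl in place of hydrogen on a saturated chain carbon bound to two saturated chain carbons, in other words propylamino to isobutylamino, a methyl in place of hydrogen on a saturated chain carbon bound to two saturated chain carbons.

Going by the values given here, no step between measured compounds is available to size this change. The expected shift in this assay is none beyond the scatter, and another limit is a likely outcome. The expected step of a number no higher from compound 2 to compound 3 (the limit leaves the size open) is accordingly small, and it is anchored only on the limit of compound 2 at > 25000 nM. For compound 3 the estimated value is 25000 nM, with an expected range of 12000 nM to 50000 nM.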

Compound 3, half-maximal inhibitory concentration: > 25000 nM
Compound 3: a limit, no number; the forecaster's own chance of this, stated with the estimate: 75%; the middle value sits exactly at the limit.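

In this assay compound 3 gives > 25000 nM, a limit and not a number. Compound 2 also reads only as a limit, so no step can be read between compound 2 and compound 3. The compounds shown leave open how far each lies from the limit and whether propylamino to isobutylamino shifts the read-out at all.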